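Adding a Methyl to the Benzyl Ring of Compound 2

The source may hold more compounds than are shown below. What is called first, only, known or untested is meant among the compounds shown, and "the series" means these compounds.

Measured so far:
- compound 1, `CN(C)CCCNc1nc(N/N=C/c2ccc(F)cc2)nc2ccccc12`: 4090 nM
- compound 2, `CN(C)CCNc1nc(N/N=C/c2nccn2Cc2ccccc2)nc2ccccc12`: 9650 nM

Of the compounds shown here, two sharing one core have been tested in a functional assay on NCI-H460 cells (Homo sapiens) for cytotoxicity, read by MTT assay, with a stated time of 72 h; on this read-out higher numbers stand for weaker inhibition and lower numbers for stronger inhibition. Compound 1 gives 4090 nM. Compound 2 gives 9650 nM, the highest of the two numbers, so it is the weaker inhibitor of the pair; the gap to compound 1 is beyond the usual scatter.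

Compound 3, `Cc1ccc(Cn2ccnc2/C=N/Nc2nc(NCCN(C)C)c3ccccc3n2)cc1`, differs from compound 2 in a single place: methyl in place of hydrogen on an aromatic carbon. In words, methyl in place of hydrogen on an aromatic carbon, so that the benzyl group becomes a 4-methylbenzyl group. Going by the values given here, nothing measured here shows what such a change does on this core, and no step between measured compounds gives a direction. With one carbon added at the edge of the molecule, no step beyond the scatter is expected in this assay, in either direction. The expected step is a 1.1-fold lower number from compound 2 to compound 3 (0.06 log units; within the scatter). Compound 3 is expected at 8500 nM, within a range from 3000 nM to 25000 nM.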

Compound 3, half-maximal inhibitory concentration: 4200 nM
Beside the measured number, compound 3's estimate is 2.0-fold (0.31 log units) above it; low and high end bracket the measured number.
By their numbers in this assay, from the lowest: compounds 1 and 3 (each within the scatter of the next); then compound 2.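

In this assay, methyl in place of hydrogen on an aromatic carbon of the benzyl ring gives a 2.3-fold lower number from compound 2 to compound 3 (0.36 log units; beyond the scatter), a modest step towards stronger inhibition. The earlier compounds shown here gave no direction for this change, and this step shows that the position is sensitive: a single added carbon, at the edge of the molecule, moves the number by more than the usual scatter. Nothing available explains why the 4-methylbenzyl group gives the lower number.

This single step cannot show whether the methyl itself matters or whether other groups would serve equally well at this carbon. Going by these compounds, a chlorine atom, a methoxy group or an ethyl group in the same place could go the same way or the opposite way, so the trend remains open.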